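This account rests on a few compounds, and the source may have more. Where it says the series, first, only, none or still open, it means among the compounds named here.

Three cyanoguanidines have so far been examined in a functional assay on Sf9 cells for antagonist activity at histamine H2 receptor (Homo sapiens), read by scintillation counting and GTPgammaS binding, with a stated time of 90 min; a lower number here means a less potent compound, a higher number a more potent compound, by a factor of ten per unit of this negative logarithm. Compound 1 `CN/C(=N/C#N)NCCCc1c[nH]c(C)n1` gives < 5, which is a limit of the measurement and not a number. Compound 2 `N#C/N=C(\NCCCCc1cnn[nH]1)NCCSc1ccccc1` gives < 5, again only a limit. Compound 3 `N#C/N=C(\NCCNc1ccnc(N)n1)NCCSc1ccccc1` gives < 5, also a limit. Going by the values given here, the one single-place step among them, a step that the two limits leave unreadable from compound 2 to compound 3, therefore cannot be read in size or direction, because both of its ends rest on (the limit of < 5 in this assay, at which 3 of the 3 values shown sit). Compound 2 thus stands at the floor of what this assay reports, and nothing shown places it any more precisely than that.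

Compound 4 `Cc1nccn1CCCCCN/C(=N\C#N)NCCSc1ccccc1` has not been measured. It differs from compound 2 by (2-methyl-1H-imidazol-1-yl)methyl in place of 1H-1,2,3-triazol-5-yl on a saturated chain carbon, four bonds along the chain from an amine nitrogen. Among the compounds with values here, no measured step speaks to this change, because every value obtained so far sits on (the limit of < 5 in this assay, at which 3 of the 3 values shown sit), so there is no readable precedent for an exchange of one small aromatic ring for another at this point of the chain. With compound 2 known only as a limit, the step of a number no lower from compound 2 to compound 4 (the limit leaves the size open) that the estimate implies is necessarily a loose one, expected to be small rather than large. Compound 4 is expected to reach about 5 in this assay, within the range 4.3 to 5.7, with a real chance that this assay once more reports only a limit rather than a number.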

Compound 4, negative logarithm of the antagonist equilibrium constant: < 5
Compound 4 ended at the assay's limit (the forecaster's own chance of this, stated with the estimate: 65%); the middle value lies on the limit itself.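

No step can be read from compound 2 to compound 4, where (2-methyl-1H-imidazol-1-yl)methyl replaces 1H-1,2,3-triazol-5-yl, because both ends are limits and not numbers: the limit of < 5 in this assay, at which 4 of the 4 values shown sit.

In this assay the compounds shown leave open how far each lies beyond that limit, and whether any change of ring or chain would give a readable number.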